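This account rests on a few compounds, and the source may have more. Where it says the series, first, only, none or still open, it means among the compounds named here.

In an in vitro ADME assay on microsomes (Homo sapiens) for metabolic stability (on this read-out higher numbers stand for a longer-lived compound and lower numbers for a shorter-lived compound), compound 1 `CCC(CC)Nc1nc(OC)c(-c2ccc(Cl)cc2Cl)nc1C` gives 0.933 h and compound 2 `CCc1nc(NC(CC)CC)c(OC)nc1-c1ccc(Cl)cc1Cl` gives 0.583 h and these two numbers lie within the usual scatter of repeated measurements, so they are best read as one level. Compound 3 `CCC(CC)Nc1nc(OC)c(-c2ccc(Cl)cc2Cl)nc1OC` has yet to be measured in this assay and follows from compound 2 by one structural change. The change methoxy in place of ethyl on an aromatic carbon puts methoxy in place of ethyl on an aromatic carbon, ortho to a 2,4-dichlorophenyl group. Within the data shown here, no measured pair differs in one place only, so nothing here shows directly what this swap does. Among the measured compounds shown here, the only guide is the close agreement of the two measured compounds, so no move beyond the scatter is expected in either direction. The expected step is a 1.2-fold higher number from compound 2 to compound 3 (0.08 log units; within the scatter) and counts as no real change. Compound 3 is estimated at 0.7 h in this measurement, with an expected range from 0.3 h to 1.5 h for repeat results.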

Compound 3, half-life: 0.267 h
Estimate against measurement, compound 3: 2.6-fold (0.42 log units) above; measured number below the stated range.
By their numbers in this assay, from the lowest: compound 3; then compounds 2 and 1 (each within the scatter of the next).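

In this assay this aromatic carbon turns out not to be indifferent to what it carries: methyl in compound 1 and ethyl in compound 2 read as one level, while methoxy stands clearly lower, both against ethyl (a 2.2-fold lower number from compound 2 to compound 3 (0.34 log units; beyond the scatter)) and against methyl (a 3.5-fold lower number from compound 1 to compound 3 (0.54 log units; beyond the scatter)). Across these three compounds, then, the two carbon-linked groups sit together and the oxygen-linked group sits apart, although both steps are modest. Nothing available here explains this difference.

The compounds shown leave open whether the lower number goes with the oxygen atom alone or with methoxy as a whole, a question that ethoxy or an amine at this place could help to separate. They also leave open whether the swap would give a similar step with a group other than (pentan-3-yl)amino on the shared core.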